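Amide-end variation in the series

The source may report more compounds than this note shows. Statements on the series, on what has been measured and on what is new or still open speak of the compounds shown alone.

Three compounds share one core: compound 1 is `NCCCCNc1cc(/C=C/c2ccccc2)nc2ccccc12`, compound 2 is `CCN(CC)CC(=O)NCCNc1cc(/C=C/c2ccccc2)nc2ccccc12` and compound 3 is `O=C(CN1CCCC1)NCCCCNc1cc(/C=C/c2ccccc2)nc2ccccc12`. In an ADME assay on J774 cells (Mus musculus) for cytotoxicity, read by MTT assay, with a stated time of 48 h (on this read-out lower numbers stand for stronger inhibition and higher numbers for weaker inhibition), compound 1 gives 6600 nM, compound 2 gives 700 nM and compound 3 gives 7100 nM. Compound 2 stands at the lowest of the three numbers; the step of a 9.4-fold lower number from compound 1 to compound 2 (0.97 log units; beyond the scatter) is the nearer gap, and compound 3 lies further off.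

Compound 4 is `O=C(CNc1ccc(Cl)cc1Cl)NCCNc1cc(/C=C/c2ccccc2)nc2ccccc12` and differs from compound 2 in one place: (2,4-dichlorophenyl)amino in place of diethylamino on a saturated chain carbon bound to a carbonyl carbon. Within the data shown here, no measured step tests this exchange directly. Both a 9.4-fold lower number from compound 1 to compound 2 (0.97 log units; beyond the scatter) and a 1.1-fold higher number from compound 1 to compound 3 (0.03 log units; within the scatter) alter the same chain end and differ in size, so this end does move the number, but neither step swaps one amine for an arylamine, and the chain length also differs between them. A modest shift toward a higher number in this assay is therefore expected, a 2.9-fold higher number from compound 2 to compound 4 (0.46 log units; beyond the scatter), with wide uncertainty. Compound 4 is expected at 2000 nM, within 500 nM to 8000 nM.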

Compound 4, half-maximal inhibitory concentration: > 50000 nM
Compound 4: only a limit was reported; the forecaster's own chance of this, stated with the estimate: 5%; middle value at least 25-fold (1.39 log units) from the limit.
By their numbers in this assay, from the lowest: compound 2; then compounds 1 and 3 (each within the scatter of the next). At a limit, above all of these: compound 4.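

In this assay, compound 4 is reported only as a limit, not as a number: the limit of > 50000 nM in this assay, at which 1 of the 4 values shown sits. Exchanging diethylamino for (2,4-dichlorophenyl)amino on a saturated chain carbon bound to a carbonyl carbon gives an at least 71-fold higher number from compound 2 to compound 4 (1.85 log units; beyond the scatter), a large step. Compounds 1, 2 and 3 showed that the chain end can matter, but not that an arylamine at this place goes with so high a number in this series.

The exchange brings in an aromatic ring, two chlorines and an amine hydrogen together, so the step cannot be assigned to any one of them. Going by these compounds, a plain phenylamino group or a (methyl)(2,4-dichlorophenyl)amino group at the same place would begin to separate these, and whether the step holds on a longer chain also stays open.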